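Thiazolidinedione benzylidene series: aryl swap toward thiophene

This account rests on a few compounds, and the source may have more. Where it says the series, first, only, none or still open, it means among the compounds named here.

Measured compounds in a functional assay on A549 cells (Homo sapiens) for cytotoxicity, read by MTT assay, with a stated time of 24 h; on this read-out higher numbers stand for weaker inhibition and lower numbers for stronger inhibition:
- compound 1 `Cn1cccc1/C=C1\SC(=O)N(Cc2ccc(C(=O)O)cc2)C1=O` gives 80000 nM
- compound 2 `O=C(O)c1ccc(CN2C(=O)S/C(=C\c3ccc(F)cc3)C2=O)cc1` gives 36000 nM
- compound 3 `Cc1ccc(/C=C2\SC(=O)N(Cc3ccc(C(=O)O)cc3)C2=O)cc1` gives 78000 nM

Compound 1 stands at the highest of the three numbers; compound 3 sits within the scatter of it, and only compound 2 is separated from it beyond the scatter.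

The next compound, compound 4 `O=C(O)c1ccc(CN2C(=O)S/C(=C\c3cccs3)C2=O)cc1`, differs from compound 1 in one place: thiophen-2-yl in place of 1-methyl-1H-pyrrol-2-yl on a double-bonded chain carbon bound to a double-bonded ring carbon.

Among the compounds with values here, two measured steps bear on this change, since each likewise replaces the 1-methyl-1H-pyrrol-2-yl group on the double-bonded chain carbon bound to a double-bonded ring carbon. The step of a 2.2-fold lower number from compound 1 to compound 2 (0.35 log units; beyond the scatter) gave a modest lowering; the step of a 1.0-fold lower number from compound 1 to compound 3 (0.01 log units; within the scatter) gave no change beyond the scatter. Aryl replacement at this position has therefore moved the number by at most a modest amount, and in the lowering direction when it moved at all. For compound 4 a step of about a 1.3-fold lower number from compound 1 to compound 4 (0.12 log units; within the scatter) is expected, small and probably toward a lower number, but possibly within the scatter.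

Compound 4 is estimated at 60000 nM in this assay, with a range from 25000 nM to 130000 nM.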

Compound 4, half-maximal inhibitory concentration: 80000 nM
Compound 4: middle estimate off by 1.3-fold (0.12 log units), on the low side, and the stated range covers the measured number.
By their numbers in this assay, from the lowest: compound 2; then compounds 3, 1 and 4 (each within the scatter of the next).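

In this assay, the thiophen-2-yl group gives no change at the digits printed from compound 1 to compound 4 (within the scatter) and the comparison with the 4-methylphenyl group gives a 1.0-fold higher number from compound 3 to compound 4 (0.01 log units; within the scatter), so compounds 1, 3 and 4 form a group within the scatter despite carrying three different aryl groups on the double-bonded chain carbon. Within the data shown here, the separation seen earlier now rests on one compound, as the thiophen-2-yl replacement of 4-fluorophenyl gives a 2.2-fold higher number from compound 2 to compound 4 (0.35 log units; beyond the scatter) and leaves compound 2 as the only member apart from the other three. No evidence is available to explain why compound 2 alone stands apart.

Going by these compounds, whether the lower number of compound 2 belongs to the fluoro substituent or to the 4-fluorophenyl group as a whole remains open. Also open, on these data alone, is whether an aryl group carrying an amine or a methoxy group at this place would move the number beyond the scatter.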